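Amino replacing trifluoromethoxy in a biaryl amide series

The source may report more compounds than this note shows. Statements on the series, on what has been measured and on what is new or still open speak of the compounds shown alone.

Compound 1 `CC[C@H](C)[C@H](N)CN(C(=O)[C@@H]1C[C@H]1c1ccccc1)c1ccc(-c2ccc(OC(C)C)cc2)cc1`: in a functional assay for agonist activity at G protein-coupled receptor 88 (Homo sapiens), read by HTRF and cAMP accumulation (on this read-out higher numbers stand for an effect only at larger amounts of compound and lower numbers for an effect already at smaller amounts), compound 1 gives 72 nM.
Compound 2 `CC[C@H](C)[C@H](N)CN(C(=O)[C@@H]1C[C@H]1c1ccccc1)c1ccc(-c2ccc(OC(F)(F)F)cc2)cc1`: in this assay compound 2 gives 170 nM.

Compound 2 stands at the higher of the two numbers, the step of a 2.4-fold higher number from compound 1 to compound 2 (0.37 log units; beyond the scatter) separating it from compound 1. Compound 3 `CC[C@H](C)[C@H](N)CN(C(=O)[C@@H]1C[C@H]1c1ccccc1)c1ccc(-c2ccc(N)cc2)cc1` differs from compound 2 by amino in place of trifluoromethoxy on an aromatic carbon. For the measured compounds named here, only that one step bears on this change, and it shows that the group at this position moves the number modestly. A further change to a far smaller group is expected to raise the number again by a modest step, a 2.4-fold higher number from compound 2 to compound 3 (0.37 log units; beyond the scatter). Compound 3 is therefore estimated at 400 nM, within 100 nM to 2000 nM.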

Compound 3, half-maximal effective concentration: 320 nM
The estimate for compound 3 lay 1.3-fold (0.10 log units) above the measured number; low and high end bracket the measured number.
By their numbers in this assay, from the lowest: compound 1; then compounds 2 and 3 (each within the scatter of the next).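

In this assay, amino in place of trifluoromethoxy, one heavy atom for five and one hydrogen-bond donor gained, gives a 1.9-fold higher number from compound 2 to compound 3 (0.27 log units; within the scatter) and so cannot be told apart from no change. Amino in place of isopropoxy gives a 4.4-fold higher number from compound 1 to compound 3 (0.65 log units; beyond the scatter) and is the larger step, so among these three compounds only compound 1 stands apart. No measurement given here accounts for these numbers.

As far as these compounds go, whether a carboxylic acid, a dimethylamino group or a longer alkoxy chain such as butoxy on this aromatic carbon would fall with compound 1 or with compound 2 and compound 3 stays open.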